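A few compounds are considered here, and "the series" means these few. Any claim that something is new, unique, unknown or untested is made for them only; others in the source may bear on it.

In a functional assay on BaF3 cells (Mus musculus) for inhibition, read by CCK-8 assay, with a stated time of 72 h (a lower number here means a stronger inhibitor of growth, a higher number a weaker inhibitor of growth), compound 3 `COCCNc1cc(Oc2ccc(NC(=O)Nc3ccc(C)c(C(F)(F)F)c3)cc2)ncn1` gives 7950 nM, the highest number of the three, against compound 1 `CC(=O)Nc1cc(Oc2ccc(NC(=O)Nc3ccc(C)c(C(F)(F)F)c3)cc2)ncn1` at 3230 nM and compound 2 `CCC(=O)Nc1cc(Oc2ccc(NC(=O)Nc3ccc(C)c(C(F)(F)F)c3)cc2)ncn1` at 990 nM. Compound 4 `Cc1ccc(NC(=O)Nc2ccc(Oc3cc(N4CCN[C@H](C)C4)ncn3)cc2)cc1C(F)(F)F` differs from compound 3 as follows: 3-methylpiperazin-1-yl in place of (2-methoxyethyl)amino on an aromatic carbon. That is, 3-methylpiperazin-1-yl in place of (2-methoxyethyl)amino on an aromatic carbon. Within the data shown here, no measured step puts a ring on this carbon. The closest guides are changes to the group at the same carbon: a 2.5-fold higher number from compound 1 to compound 3 (0.39 log units; beyond the scatter) and an 8.0-fold higher number from compound 2 to compound 3 (0.90 log units; beyond the scatter), while the smaller change shows a 3.3-fold lower number from compound 1 to compound 2 (0.51 log units; beyond the scatter). These steps are modest, and both other measured compounds lie lower than compound 3, so a modest step towards a lower number is expected, with the direction uncertain. The estimated change is a 4.0-fold lower number from compound 3 to compound 4 (0.60 log units; beyond the scatter). Compound 4 is estimated at 2000 nM, with an expected range of 400 nM to 8000 nM.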

Compound 4, concentration for 50% growth inhibition: 8920 nM
Compound 4: middle estimate off by 4.5-fold (0.65 log units), on the low side; measured number outside the range, above it.
By their numbers in this assay, from the lowest: compound 2; then compound 1; then compounds 3 and 4 (each within the scatter of the next).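

In this assay, replacing the open (2-methoxyethyl)amino chain with the 3-methylpiperazin-1-yl ring on this carbon gives no readable change: a 1.1-fold higher number from compound 3 to compound 4 (0.05 log units; within the scatter). The ring also stays on the weaker side of both amides, with a 2.8-fold higher number from compound 1 to compound 4 (0.44 log units; beyond the scatter) and a 9.0-fold higher number from compound 2 to compound 4 (0.95 log units; beyond the scatter), so at this carbon it does not match the acetamido or propanoylamino group. Nothing available bears on why the ring and the open chain read alike.

Still open, as far as these compounds go, is whether a longer acyl chain such as butanoylamino would give a lower number than propanoylamino. Also open, from the compounds shown here alone, is whether the ring methyl matters, which unsubstituted piperazin-1-yl would test.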